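The compounds below may be only part of what the source reports. "The series", "measured", "known", "first", "only" and "open" are said of these compounds alone.

Working notes on the series. The set so far holds three measured compounds. Compound 1 `Oc1ccccc1Nc1nccc(-c2c[nH]c3ccccc23)n1` carries a hydroxyphenyl amine on the shared core; in a functional assay on MV4-11 cells (Homo sapiens) for inhibition, read by resazurin assay, with a stated time of 72 h (a higher number here means a weaker inhibitor of growth, a lower number a stronger inhibitor of growth), compound 1 gives 570 nM. Compound 3 `CCCn1cc(-c2ccnc(Nc3ccc(OC)cc3OC)n2)c2ccccc21` carries a dimethoxyphenyl amine with a propyl-substituted bicyclic aromatic on the core, and in this assay compound 3 gives 3620 nM. Compound 2 `CCCCOc1nc(C)c(-c2ccnc(Nc3ccc(OC)cc3OC)n2)s1` pairs the same dimethoxyphenyl amine with a five-membered aromatic ring bearing butoxy and methyl; in this assay compound 2 gives 7860 nM, the highest number of the three, with compound 3 beyond the scatter below it and compound 1 further below still.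

Compound 4 `COc1ccc(Nc2nccc(-c3sc(SC)nc3C)n2)c(OC)c1` is the next compound, not yet measured. It differs from compound 2 in one place: methylsulfanyl in place of butoxy on an aromatic carbon. Within the data shown here, no measured pair in the set shows this change, so nothing in the numbers tells its direction. The step from compound 2 to compound 4 is therefore expected to lie within the scatter, a 1.2-fold lower number from compound 2 to compound 4 (0.08 log units; within the scatter). For compound 4 in this assay the estimate is 6500 nM, with a range from 2000 nM to 20000 nM.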

Compound 4, concentration for 50% growth inhibition: 530 nM
Compound 4: the middle estimate sits 12-fold (1.09 log units) above what was measured; measured number below the stated range.
By their numbers in this assay, from the lowest: compounds 4 and 1 (each within the scatter of the next); then compound 3; then compound 2.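

Methylsulfanyl in place of butoxy on this aromatic carbon gives a 15-fold lower number from compound 2 to compound 4 (1.17 log units; beyond the scatter) in this assay and provides the first single-place step in the series. The position, next to the ring nitrogen and next to the ring sulfur, is therefore not indifferent to the group it carries, and the smaller methylsulfanyl is the group linked to the lower number here, although both groups have the same count of hydrogen-bond donors and acceptors. Nothing at hand accounts for the size of this step.

This single step does not separate the shorter group from the exchange of oxygen for sulfur, so methoxy and butylsulfanyl remain the informative comparisons at this position. It also leaves open whether an amine or a longer sulfur-linked chain would be tolerated there.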